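Adding hydroxy to the phenyl of compound 1

The compounds below may be only part of what the source reports. "The series", "measured", "known", "first", "only" and "open" are said of these compounds alone.

Of the compounds shown here, two have numbers so far. Compound 1 (`c1ccc(-c2nc(-c3csc(N=C4NCCCN4)n3)cs2)cc1`) gives 83% in an ADME assay on microsomes from liver (Homo sapiens) for metabolic stability, read by LC-MS, with a stated time of 30 min, tested at 0.5 uM (on this read-out lower numbers stand for a less stable compound and higher numbers for a more stable compound), and holds the higher of the two. Compound 2 (`c1ccc(-n2ccc(-c3csc(N=C4NCCCN4)n3)n2)cc1`) gives 38% in this assay and sits lower by a gap beyond the usual scatter. For the measured compounds named here, no measured pair differs in one place only, so no single change has yet been sized.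

Compound 3 (`Oc1cccc(-c2nc(-c3csc(N=C4NCCCN4)n3)cs2)c1`) has not yet been measured. It has hydroxy in place of hydrogen on an aromatic carbon of compound 1, meta to a large group (hydroxy in place of hydrogen on an aromatic carbon) and reading as phenyl to 3-hydroxyphenyl.

Compound 1 at 83% sits high on this read-out, with more room to fall than to rise, so a decrease is expected. The estimate is a number 18 percentage points lower from compound 1 to compound 3 (beyond the scatter) as a moderate fall just beyond the scatter, although a result within the scatter remains possible. In this assay compound 3 is estimated at 65% with a range of 42% to 84% expected.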

Compound 3, percent of the compound remaining: 77%
Beside the measured number, compound 3's estimate is 12 percentage points below it; low and high end bracket the measured number.
By their numbers in this assay, from the lowest: compound 2; then compounds 3 and 1 (each within the scatter of the next).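

Hydroxy in place of hydrogen on an aromatic carbon, meta to a large group, gives a number 6 percentage points lower from compound 1 to compound 3 (within the scatter) in this assay, and this is the first step in the series that sizes a single change. Phenyl to 3-hydroxyphenyl therefore leaves compounds 1 and 3 indistinguishable on this read-out, so this place on the phenyl of compound 1 takes a hydroxy, with its hydrogen-bond donor and acceptor, without a difference that can be told from repeated measurement. No measurement at hand gives a reason for this result, and the step is recorded here only as a size.

Still open, from the compounds shown here alone, is whether other groups at this place, such as a methoxy, an amine or a carboxylic acid, would also stay within the scatter of compound 1, and whether hydroxy would do the same elsewhere on the phenyl ring. Also open, going by these compounds, is whether the same hydroxy on the phenyl of compound 2, which stands at 38%, would produce a step of similar size from that lower starting point.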